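An Ester-to-Anilide Change Repeated on a Second Core

The source may report more compounds than this note shows. Statements on the series, on what has been measured and on what is new or still open speak of the compounds shown alone.

Measured compounds:
- compound 1 `CCOC(=O)CSc1nnc(-c2cc(OC)c(OC)c(OC)c2)n1-c1ccc(OC)cc1`: in a functional assay on HepG2 cells (Homo sapiens) for inhibition, read by MTT assay, with a stated time of 48 h (a higher number here means a weaker inhibitor, a lower number a stronger inhibitor), compound 1 gives > 60000 nM, a limit of the assay, not a number.
- compound 2 `COc1ccc(NC(=O)CSc2nnc(-c3cc(OC)c(OC)c(OC)c3)n2-c2ccc(OC)cc2)cc1`: in this assay compound 2 gives > 60000 nM, again a limit.
- compound 3 `CCOC(=O)CSc1nnc(-c2cc(OC)c(OC)c(OC)c2)n1-c1ccc(N(C)C)cc1`: in this assay compound 3 gives > 60000 nM, also a limit.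

None of the three entries is a measured number; each sits at the limit of > 60000 nM in this assay, at which 3 of the 3 values shown sit. The change from compound 1 to compound 2 is (4-methoxyphenyl)amino in place of ethoxy on a carbonyl carbon, and its step, a step that the two limits leave unreadable from compound 1 to compound 2, cannot be read. The two cores differ by dimethylamino in place of methoxy on an aromatic carbon, and that step, a step that the two limits leave unreadable from compound 1 to compound 3, is equally unreadable.

Compound 4 `COc1ccc(NC(=O)CSc2nnc(-c3cc(OC)c(OC)c(OC)c3)n2-c2ccc(N(C)C)cc2)cc1` is not yet measured. It carries, on the core of compound 3, the change ((4-methoxyphenyl)amino in place of ethoxy on a carbonyl carbon). The place is the same word for word as for compound 1 to compound 2, so this is the same change. Since compound 3 already sits at the limit of > 60000 nM in this assay, at which 3 of the 3 values shown sit, the expected step is a step that the limit leaves unreadable from compound 3 to compound 4, with no readable size. Compound 4 is expected to give about 90000 nM, between 30000 nM and 400000 nM, most likely reported as a limit once more.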

Compound 4, half-maximal inhibitory concentration: > 60000 nM
Compound 4 was reported as a limit; the forecaster's own chance of this, stated with the estimate: 88%; the middle value is on the limit's open side.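

In this assay compound 4 gives > 60000 nM as a limit, not a number. Neither the step from compound 3 to compound 4 nor the step from compound 2 to compound 4 can be read, and all four compounds stand at the same limit: the limit of > 60000 nM in this assay, at which 4 of the 4 values shown sit.

The compounds shown leave open how strongly any of the four inhibits, and whether either change has any effect in this assay on these cores.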